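The source may report more compounds than this note shows. Statements on the series, on what has been measured and on what is new or still open speak of the compounds shown alone.

Compound 1 `COc1cc(-c2nccc3[nH]c(-c4cccc5[nH]ccc45)nc23)cc(OC)c1OC` in an ADME assay (liver) for metabolic stability, with Liver microsome (Homo sapiens) as the target, read by LC-MS, using microsomes, tested at 2 uM (on this read-out higher numbers stand for a longer-lived compound and lower numbers for a shorter-lived compound), gives 0.552 h. Compound 2 `COc1cc(-c2nccc3ccc(-c4ccc5[nH]ccc5c4)cc23)cc(OC)c1OC` in this assay gives 0.648 h, a number that sits within the usual scatter of compound 1, so the two are not told apart on this read-out. Compound 3 `COc1cc(-c2nccc3[nH]c(-c4ccc5cc[nH]c5c4)nc23)cc(OC)c1OC` is not yet measured; it differs from compound 1 by 1H-indol-6-yl in place of 1H-indol-4-yl on an aromatic carbon. For the measured compounds named here, no measured pair in the set shows this change, so the expectation rests on the two values alone: the expected step of a 1.0-fold lower number from compound 1 to compound 3 (0.00 log units; within the scatter) is none beyond the scatter, in either direction. Compound 3 is accordingly estimated at 0.55 h, with a range from 0.3 h to 1 h.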

Compound 3, half-life: 0.938 h
Beside the measured number, compound 3's estimate is 1.7-fold (0.23 log units) below it; measured number inside the range.
By their numbers in this assay, from the lowest: compounds 1, 2 and 3 (each within the scatter of the next).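

For the compounds shown here, exchanging 1H-indol-4-yl for 1H-indol-6-yl on the aromatic carbon between two ring nitrogen atoms gives the first single-place comparison. In this assay the step is a 1.7-fold higher number from compound 1 to compound 3 (0.23 log units; within the scatter) and so does not separate the two attachment points on this read-out. No measured data bear on the outcome.

From the compounds shown here alone, whether any replacement of the indole at this carbon, such as a carboxylic acid or a morpholine, would shift the half-life beyond the scatter remains open. So does the role of the trimethoxyphenyl group.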